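Methoxy for fluoro on the aryl of a triazole nitrone

A few compounds are considered here, and "the series" means these few. Any claim that something is new, unique, unknown or untested is made for them only; others in the source may bear on it.

Measured compounds:
compound 1 `COc1ccc(-n2cc(/C=[N+](\[O-])Cc3ccccc3)nn2)cc1`, > 100000 nM
compound 2 `CC(C)(C)/[N+]([O-])=C/c1cn(-c2ccccc2)nn1`, 15200 nM
compound 3 `CC(C)(C)/[N+]([O-])=C/c1cn(-c2ccc(F)cc2)nn1`, 58900 nM

Compound 3 carries a fluoro on the aromatic ring attached to the triazole. In a functional assay on COLO 205 cells (Homo sapiens) for inhibition, read by MTT assay, with a stated time of 24 h (a higher number here means a weaker inhibitor, a lower number a stronger inhibitor), compound 3 gives 58900 nM, the higher of the two numbers reported, its nearest neighbour being compound 2 at 15200 nM. The value of compound 1 in this assay is a limit, > 100000 nM (the limit of > 100000 nM in this assay, at which 1 of the 3 values shown sits).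

Compound 4 `COc1ccc(-n2cc(/C=[N+](\[O-])C(C)(C)C)nn2)cc1` is compound 3 with the change (methoxy in place of fluoro on an aromatic carbon). For the measured compounds named here, no measured step covers a methoxy in place of a fluoro directly. Going by the values given here, the one step on this ring, a 3.9-fold higher number from compound 2 to compound 3 (0.59 log units; beyond the scatter), shows that a small change here moves the number by a modest amount. Compound 1, which also carries the methoxy but with a different group on the nitrone, reaches only the limit and offers no number to compare.

The expected change for compound 4 is therefore small, a 1.0-fold higher number from compound 3 to compound 4 (0.01 log units; within the scatter), with wide uncertainty. Compound 4 is estimated at 60000 nM, within 20000 nM to 150000 nM.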

Compound 4, half-maximal inhibitory concentration: 19800 nM
Compound 4: the middle estimate sits 3.0-fold (0.48 log units) above what was measured, outside the stated range (below it).
By their numbers in this assay, from the lowest: compounds 2 and 4 (each within the scatter of the next); then compound 3. At a limit, above all of these: compound 1.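

On the aromatic carbon para to a large group, the two replacements can now be set side by side in this assay: methoxy in place of fluoro gives a clear step (a 3.0-fold lower number from compound 3 to compound 4 (0.47 log units; beyond the scatter)), whereas methoxy in place of hydrogen does not (a 1.3-fold higher number from compound 2 to compound 4 (0.11 log units; within the scatter)). Of the three groups seen here with tert-butyl on the nitrone, fluoro alone therefore stands apart from the other two, and compound 2 and compound 4 cannot be told apart. With methoxy held constant, the other end of the molecule also matters, as tert-butyl in place of benzyl gives a step that can be stated only as a minimum (an at least 5.0-fold lower number from compound 1 to compound 4 (0.70 log units; beyond the scatter)), since the value of compound 1 is a limit: the limit of > 100000 nM in this assay, at which 1 of the 4 values shown sits.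

The compounds shown leave open how an amine or a carboxylic acid would read at this aromatic carbon. They also leave open whether fluoro would stand apart in the same way with benzyl on the nitrone.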